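A few compounds are considered here, and "the series" means these few. Any claim that something is new, unique, unknown or untested is made for them only; others in the source may bear on it.

Compound 1 `CCOC(=O)c1ccc2oc(N3CCN(C)CC3)nc2c1` gives only a limit in a functional assay on ileum (strain Hartley) for agonist activity at 5-hydroxytryptamine receptor 3A (Cavia porcellus) (a higher number here means a more potent compound, by a factor of ten per unit of this negative logarithm, a lower number a less potent compound), reported as < 4.
Compound 2 `CCc1cccc2nc(N3CCN(C)CC3)oc12` gives 5.48.
Compound 3 `CCc1cc(Cl)cc2nc(N3CCN(C)CC3)oc12` gives 6.82.

Compound 3 holds the highest of the two numbers shown, the other number being that of compound 2, while the third value is a limit (the limit of < 4 in this assay, at which 1 of the 3 values shown sits). Compound 4 `COc1cc(Cl)cc2nc(N3CCN(C)CC3)oc12` differs from compound 3 by methoxy in place of ethyl on an aromatic carbon. Among the compounds with values here, the only measured step, a number 1.34 log units higher from compound 2 to compound 3 (beyond the scatter), concerns a chloro group and not the ethyl-to-methoxy exchange, so no measured step bears directly on this change. The chloro group is kept in compound 4, so the expected step of a number 0.22 log units lower from compound 3 to compound 4 (within the scatter) is no change beyond the scatter. Compound 4 is therefore estimated at 6.6, within 5.9 to 7.3.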

Compound 4, negative logarithm of the half-maximal effective concentration: 6.16
For compound 4 the middle estimate is 0.44 log units above the measured one; measured number inside the range.
By their numbers in this assay, from the lowest: compound 2; then compound 4; then compound 3. At a limit, below all of these: compound 1.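

At this aromatic carbon, ortho to a fused ring and meta to a chloro group, the group present makes a measurable difference with the chloro group held in place: in this assay, methoxy in place of ethyl gives a number 0.66 log units lower from compound 3 to compound 4 (beyond the scatter). Ethyl and methoxy are thus not interchangeable here, though they have the same heavy-atom count. Nothing measured here accounts for this step. From the compounds shown here alone, whether a longer chain, a hydroxyl or an amine at this carbon would fall above, below or level with ethyl and methoxy stays open. Also open, going by these compounds, is whether the exchange gives a similar step without the chloro group.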